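Amide substituent exchange in a small adenosine receptor series

This account rests on a few compounds, and the source may have more. Where it says the series, first, only, none or still open, it means among the compounds named here.

Three compounds have numbers in an assay on HEK293 cells for displacement of a labelled ligand from adenosine receptor A2b (Homo sapiens), read by scintillation counting, with a stated time of 30 min, tested at 10 uM; on this read-out lower numbers stand for less inhibition and higher numbers for more inhibition at the one concentration tested (going by the name of the read-out). Compound 1 `O=C(NC1CCCC1)c1cc2ccccc2oc1=O` gives 18%. Compound 2 `CCC(CO)NC(=O)c1cc2cc(Br)ccc2oc1=N` gives 4%. Compound 3 `COCCNC(=O)c1cc2cc(Cl)ccc2oc1=N` gives 9%. Within these three, compound 3 stands second highest; the nearest number is that of compound 2, which differs from it only within the scatter, and the furthest is that of compound 1, which also differs from it only within the scatter. All three numbers therefore sit together at the low end of the read-out, and none can be called stronger or weaker than another on this evidence.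

Compound 4 `CCC(CO)NC(=O)c1cc2cc(Cl)ccc2oc1=N` has not been measured. It differs from compound 3 in one place: 1-(hydroxymethyl)propyl in place of 2-methoxyethyl on an amide-type nitrogen. For the measured compounds named here, no measured pair in the set shows this change on its own, so there is no step to copy. Compound 2 does already carry the 1-(hydroxymethyl)propyl on an amide-type nitrogen and gives 4%, a low number like the rest. The expectation for the step from compound 3 to compound 4 is therefore no change beyond the scatter, expressed as a number 3 percentage points lower from compound 3 to compound 4 (within the scatter). Compound 4 is expected to give 6%, with a range from -5% to 17%.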

Compound 4, a percentage reported as inhibition, at one concentration (the size of the read-out at that concentration, not a potency): 9%
Compound 4: middle estimate off by 3 percentage points, on the low side; the measured number falls inside the stated range.
By their numbers in this assay, from the lowest: compounds 2, 3, 4 and 1 (each within the scatter of the next, the first and the last beyond it).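

For the compounds shown here, on the amide-type nitrogen, 1-(hydroxymethyl)propyl in place of 2-methoxyethyl gives no change at the digits printed from compound 3 to compound 4 (within the scatter) in this assay; this is the first direct reading of the change, and the gain of a hydrogen-bond donor and the different chain leave the read-out where it was. Compound 4 also links compound 2 to the series at a second place, since chloro in place of bromo on an aromatic carbon, with the 1-(hydroxymethyl)propyl held constant, gives a number 5 percentage points higher from compound 2 to compound 4 (within the scatter). No measured property is available to bear on either step.

On these data alone, both steps stay within the low end of the read-out, so it remains open whether a basic amine, a carboxylic acid or a longer chain on the amide-type nitrogen would move the number at all. Also open, as far as these compounds go, is whether a methoxy or a trifluoromethyl group on the aromatic carbon that carries the chloro in compound 4 would do so, and compound 1 differs from compound 4 in more than one place and gives no answer to either question.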